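Amine Replacement on the Core of Compound 1

A few compounds are considered here, and "the series" means these few. Any claim that something is new, unique, unknown or untested is made for them only; others in the source may bear on it.

Measured compounds:
compound 1, `CCCCN(C)c1nc(C(F)(F)F)ccc1CNC(=O)C(C)c1ccc(NS(C)(=O)=O)c(F)c1`: in a functional assay on CHO-K1 cells for antagonist activity at transient receptor potential cation channel subfamily V member 1 (Homo sapiens), read by FLIPR (on this read-out lower numbers stand for stronger inhibition and higher numbers for weaker inhibition), compound 1 gives 0.8 nM
compound 2, `C[C@H](C(=O)NCc1ccc(C(F)(F)F)nc1N1CC[C@H](N(C)C)C1)c1ccc(NS(C)(=O)=O)c(F)c1`: in this assay compound 2 gives 103 nM
compound 3, `C[C@@H](C(=O)NCc1ccc(C(F)(F)F)nc1N1CCC(c2ccccc2)CC1)c1ccc(NS(C)(=O)=O)c(F)c1`: in this assay compound 3 gives 7.5 nM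

Compound 1 stands at the lowest number of the three. Compound 3 lies higher than compound 1 by a gap beyond the usual scatter, and compound 2 lies higher still, also beyond the scatter. For the measured compounds named here, both compounds that carry a cyclic amine on the core therefore stand above the open-chain amine of compound 1, though with only two such examples no firm pattern can be claimed.

Compound 4, `CC(C)OC1CCN(c2nc(C(F)(F)F)ccc2CNC(=O)C(C)c2ccc(NS(C)(=O)=O)c(F)c2)CC1`, keeps the core of compound 1 and changes the amine: 4-isopropoxypiperidin-1-yl in place of butyl(methyl)amino on an aromatic carbon

Going by the values given here, no measured pair isolates this change. The two cyclic amines, compound 2 and compound 3, both sit above compound 1 in this assay, and the new ring carries an oxygen substituent rather than the phenyl of compound 3 or the dimethylamino of compound 2. An upward step is expected for compound 4, estimated at a 10-fold higher number from compound 1 to compound 4 (1.00 log units; beyond the scatter), beyond the scatter but well short of the gap to compound 2. Compound 4 is expected to give about 8 nM in this assay, within a range of 2 nM to 40 nM.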

Compound 4, inhibition constant: 3 nM
Estimate against measurement, compound 4: 2.7-fold (0.43 log units) above; low and high end bracket the measured number.
By their numbers in this assay, from the lowest: compound 1; then compound 4; then compound 3; then compound 2.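

For the compounds shown here, this is the first step at this position that isolates a single change: on the shared core, with the rest of the molecule held constant, this assay shows a 3.8-fold higher number from compound 1 to compound 4 (0.57 log units; beyond the scatter) for 4-isopropoxypiperidin-1-yl in place of butyl(methyl)amino. The step is beyond the usual scatter but modest, and with compound 4 at 3 nM the position on the aromatic carbon next to the ring nitrogen still accepts a larger group that carries a six-membered non-aromatic ring and an added ether oxygen, with the value staying in the low single-digit nanomolar range. The ring, the oxygen and the larger size all enter together in this one step, and nothing at hand says what lies behind the change in value.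

Going by these compounds, the effect of each part of the new group remains open: piperidin-1-yl without a substituent would test the ring alone, and 4-methoxypiperidin-1-yl would test the size of the group on the oxygen. An open-chain amine bearing an ether, such as (2-methoxyethyl)(methyl)amino, would show whether the oxygen matters without a ring.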